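Exchanging a Hydroxyethyl Amide for a Protected Hydrazide

This account rests on a few compounds, and the source may have more. Where it says the series, first, only, none or still open, it means among the compounds named here.

In a functional assay on HEK293 cells for agonist activity at Thyrotropin receptor (Homo sapiens), read by cAMP accumulation (a lower number here means a smaller maximal response, a higher number a larger maximal response), two compounds built on a shared core have been measured. Compound 1 `COc1cccc(-c2nc(SC)nc3sc(C(=O)NCC#N)c(N)c23)c1` reaches 3.6%. Compound 2 `COc1cccc(-c2nc(SC)nc3sc(C(=O)NCCO)c(N)c23)c1` reaches 2.9%; it stands level with compound 1, since the step of a number 0.7 percentage points lower from compound 1 to compound 2 (within the scatter) lies within the scatter, so the two responses cannot be told apart. Compound 3 `COc1cccc(-c2nc(SC)nc3sc(C(=O)NNC(=O)OC(C)(C)C)c(N)c23)c1` has not yet been measured. It differs from compound 2 by (tert-butoxycarbonyl)amino in place of 2-hydroxyethyl on an amide-type nitrogen. Going by the values given here, only one measured step bears on this change: the exchange at the same amide-type nitrogen from compound 1 to compound 2, which was flat. That gives no sign that altering this part of the molecule moves the response, but a single flat step is thin evidence for a new group of a different kind. The expected step is flat, a number 0.1 percentage points higher from compound 2 to compound 3 (within the scatter), within the scatter. Compound 3 is therefore estimated at 3%, with a range from 0% to 12%.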

Compound 3, largest response reached (reported as efficacy), in percent of the reference or control that the assay uses: 1.9%
For compound 3 the middle estimate is 1.1 percentage points above the measured one; low and high end bracket the measured number.
By their numbers in this assay, from the lowest: compounds 3, 2 and 1 (each within the scatter of the next).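

In this assay, exchanging 2-hydroxyethyl, with 3 heavy atoms, for (tert-butoxycarbonyl)amino, with 8 heavy atoms, gives a number 1 percentage points lower from compound 2 to compound 3 (within the scatter) on the amide-type nitrogen, so this much larger group leaves the response indistinguishable. The comparison with the cyanomethyl group gives the same reading, a number 1.7 percentage points lower from compound 1 to compound 3 (within the scatter), and the three groups tried on this nitrogen now cannot be told apart. No measurement is available that explains this flat result.

Still open, going by these compounds, is whether any group on this nitrogen can lift the response clearly beyond the scatter, for instance a carboxylic acid or a longer chain ending in an amine. Also open, on these data alone, is whether changes elsewhere on the shared core would move the response more than changes at this nitrogen.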